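A few compounds are considered here, and "the series" means these few. Any claim that something is new, unique, unknown or untested is made for them only; others in the source may bear on it.

Of the compounds shown here, three have been measured so far. In a functional assay on L1210 cells (Mus musculus) for inhibition (a higher number here means a weaker inhibitor, a lower number a stronger inhibitor), compound 1 `O=C1/C(=C/c2cccc(Br)c2)Cc2ccccc21` gives 43300 nM, compound 2 `O=C1/C(=C/c2ccc(F)cc2)CCCc2ccccc21` gives 60300 nM and compound 3 `O=C1/C(=C/c2ccc(Cl)cc2)CCCc2ccccc21` gives 51800 nM. Compound 3 thus stands among three values that all lie within the scatter of one another, so no order can be read from them.

The next entry is compound 4 `O=C1/C(=C/c2ccc(Br)cc2)CCCc2ccccc21`, which keeps the core of compound 3 and exchanges a single halogen: bromo in place of chloro on an aromatic carbon, para to a large group. For the measured compounds named here, the one measured step of the same kind is a 1.2-fold lower number from compound 2 to compound 3 (0.07 log units; within the scatter), chloro in place of fluoro on an aromatic carbon, and it stays within the scatter. Compound 1 also carries a bromo group, but its core differs from that of compound 3, so it gives no direct comparison. Going by the values given here, no bromo group has yet been measured on the core of compound 3.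

No change beyond the scatter is expected in this assay, and neither direction is favoured. The expected size of the step is a 1.0-fold lower number from compound 3 to compound 4 (0.02 log units; within the scatter). For compound 4 the estimated value is 50000 nM, with an expected range of 28000 nM to 85000 nM.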

Compound 4, half-maximal inhibitory concentration: 50900 nM
Estimate against measurement, compound 4: 1.0-fold (0.01 log units) below, within the range that was stated.
By their numbers in this assay, from the lowest: compounds 1, 4, 3 and 2 (each within the scatter of the next).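

In this assay, the shared core now carries three halogens on the same aromatic carbon, para to a large group, and the exchange of chloro for bromo gives little change (a 1.0-fold lower number from compound 3 to compound 4 (0.01 log units; within the scatter)), as does the exchange of fluoro for bromo (a 1.2-fold lower number from compound 2 to compound 4 (0.07 log units; within the scatter)). The earlier compounds shown here offered only the exchange of fluoro for chloro on this core; with bromo added, both new steps also lie within the scatter, so no dependence on the halogen can be read across compound 2, compound 3 and compound 4. No data from outside this assay bear on this result.

Going by these compounds, it remains open whether a group of another kind at this position, such as an amine, a carboxylic acid or a methoxy group, would move the number beyond the scatter on this core. Compound 1 differs from compound 4 in more than one place, in its core and in where its bromo group sits, so the effect of either difference on its own cannot be read.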